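The compounds below may be only part of what the source reports. "The series", "measured", "known", "first", "only" and "open" are said of these compounds alone.

Measured compounds:
Compound 1, `Brc1cn2ccnc2c(-c2ccc3ncn(C4CCCCC4)c3c2)n1`, in a functional assay on OVCAR-3 cells (Homo sapiens) for inhibition, read by sulforhodamine B assay, with a stated time of 48 h, tested at 10 uM (on this read-out lower numbers stand for less inhibition and higher numbers for more inhibition at the one concentration tested (going by the name of the read-out)), compound 1 gives 15.8%.
Compound 2, `c1ccc(-c2cn3ccnc3c(-c3ccc4ncn(C5CCCCC5)c4c3)n2)cc1`, in this assay compound 2 gives 41.8%.
Compound 3, `O=Cc1ccc(-c2cn3ccnc3c(-c3ccc4ncn(C5CCCCC5)c4c3)n2)cc1`, in this assay compound 3 gives 23.7%.

Compound 3 stands second of the three numbers: its nearest neighbour is compound 1, and the difference between them a number 7.9 percentage points higher from compound 1 to compound 3 (within the scatter); its furthest is compound 2, from which it lies a number 18.1 percentage points lower from compound 2 to compound 3 (beyond the scatter).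

Compound 4, `Clc1ccc(-c2cn3ccnc3c(-c3ccc4ncn(C5CCCCC5)c4c3)n2)cc1`, has not yet been measured. Compared with compound 3 the change is chloro in place of formyl on an aromatic carbon, so the group on the outer ring, para to a large group, is exchanged and the rest of the shared core is untouched.

The step that bears most closely on this exchange is the one where formyl entered the same ring: a number 18.1 percentage points lower from compound 2 to compound 3 (beyond the scatter), a modest drop. The steps of a number 26 percentage points higher from compound 1 to compound 2 (beyond the scatter) and a number 7.9 percentage points higher from compound 1 to compound 3 (within the scatter) show that adding a phenyl or a 4-formylphenyl to the core raised the number by different amounts. Chloro has no hydrogen-bond acceptor, like the hydrogen of compound 2, and the expected change is therefore upward in this assay, a number 10.3 percentage points higher from compound 3 to compound 4 (beyond the scatter), though likely not reaching the number of compound 2. The estimate for compound 4 in this assay is 34%, with a range from 14% to 54%.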

Compound 4, a percentage reported as inhibition, at one concentration (the size of the read-out at that concentration, not a potency): 10.9%
Compound 4: the middle estimate sits 23.1 percentage points above what was measured; measured number below the stated range.
By their numbers in this assay, from the lowest: compounds 4, 1 and 3 (each within the scatter of the next, the first and the last beyond it); then compound 2.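

In this assay the outer ring of compound 2 now has two substituents on the same carbon, and both formyl (a number 18.1 percentage points lower from compound 2 to compound 3 (beyond the scatter)) and chloro (a number 30.9 percentage points lower from compound 2 to compound 4 (beyond the scatter)) give lower numbers than hydrogen beyond the scatter. Exchanging the formyl group, with its hydrogen-bond acceptor, for chloro, which has none, did not bring the number back toward compound 2 but moved it the other way (a number 12.8 percentage points lower from compound 3 to compound 4 (beyond the scatter)), so across these compounds the number does not follow the presence of that acceptor. The 4-chlorophenyl group also leaves the number within the scatter of the bromo starting point (a number 4.9 percentage points lower from compound 1 to compound 4 (within the scatter)), so of the three outer rings shown, only the unsubstituted phenyl stands clear of compound 1.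

Nothing available here accounts for these differences. On these data alone, it remains open whether an amine or a carboxylic acid on the same carbon would match hydrogen or fall with formyl and chloro, and how these compounds would compare at other concentrations.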